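A Bromine Added to the Second Phenyl of Compound 2

This account rests on a few compounds, and the source may have more. Where it says the series, first, only, none or still open, it means among the compounds named here.

Within the data shown here, compound 2 `Clc1ccc(-c2ccc3nc(-c4ccccc4)cn3c2)cc1` gives 68800 nM in an assay for inhibition of aldehyde dehydrogenase 1A1 (Homo sapiens), with a stated time of 5 min (on this read-out higher numbers stand for weaker inhibition and lower numbers for stronger inhibition), the second highest of the three numbers measured so far: compound 1 `c1ccc(-c2ccc3nc(-c4ccccc4)cn3c2)cc1` gives 19600 nM and compound 3 `COC(=O)c1ccc(-c2ccc3nc(-c4ccccc4)cn3c2)cc1` gives 96900 nM. Compound 4 `Clc1ccc(-c2ccc3nc(-c4ccc(Br)cc4)cn3c2)cc1` differs from compound 2 by bromo in place of hydrogen on an aromatic carbon. Among the measured compounds shown here, no measured step touches that ring directly; the nearest guides are a 3.5-fold higher number from compound 1 to compound 2 (0.55 log units; beyond the scatter) and a 4.9-fold higher number from compound 1 to compound 3 (0.69 log units; beyond the scatter), both additions to a phenyl that raised the number modestly, while a 1.4-fold higher number from compound 2 to compound 3 (0.15 log units; within the scatter) stayed within the scatter. Compound 4 is therefore expected to show a small rise or none beyond the scatter, a 1.5-fold higher number from compound 2 to compound 4 (0.16 log units; within the scatter). Compound 4 is estimated at 100000 nM, with a range from 40000 nM to 250000 nM.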

Compound 4, half-maximal inhibitory concentration: 17300 nM
Estimate against measurement, compound 4: 5.8-fold (0.76 log units) above; measured number below the stated range.
By their numbers in this assay, from the lowest: compounds 4 and 1 (each within the scatter of the next); then compounds 2 and 3 (each within the scatter of the next).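

In this assay, the change from phenyl to 4-bromophenyl gives a 4.0-fold lower number from compound 2 to compound 4 (0.60 log units; beyond the scatter), the only step shown that lowers the number. The additions to the other phenyl went the opposite way, with a 3.5-fold higher number from compound 1 to compound 2 (0.55 log units; beyond the scatter) and a 4.9-fold higher number from compound 1 to compound 3 (0.69 log units; beyond the scatter), so a gain on one phenyl cannot be read from a step on the other. Nothing available explains this difference between the two rings.

Going by these compounds, whether an amine, a carboxylic acid or a methoxy group at this place would also lower the number remains open. So does whether bromo would give a similar step on compound 1, which lacks the chloro.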